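Swapping a bromophenyl for cyclohexyl in a diacylhydrazine

The source may report more compounds than this note shows. Statements on the series, on what has been measured and on what is new or still open speak of the compounds shown alone.

Measured compounds:
- compound 1, `CC(C)(C)N(NC(=O)c1ccccc1)C(=O)c1ccccc1Br`: 170 nM
- compound 2, `CC(C)(C)N(NC(=O)c1cccc(Br)c1)C(=O)c1ccccc1Cl`: 191 nM
- compound 3, `CCOc1cccc(C(=O)NN(C(=O)c2cc(C)cc(C)c2)C(C)(C)C)c1C`: 52.5 nM

All three compounds share the same core and were tested in an assay on cells for agonist activity at ecdysone receptor (Bombyx mori), read by a luciferase reporter, with a stated time of 24 h; a lower number here means that less compound is needed, a higher number that more compound is needed for the effect. Compound 1 stands second highest of the three numbers. Its nearest neighbour is compound 2, whose value lies within the scatter of that of compound 1, so no order can be drawn between these two. Compound 3 gives a clearly lower number, a gap beyond the scatter, so of the three it needs the least compound for the effect.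

The untested compound 4, `CC(C)(C)N(NC(=O)c1ccccc1)C(=O)C1CCCCC1`, follows from compound 1 by a single change: cyclohexyl in place of 2-bromophenyl on a carbonyl carbon. The aromatic ring that leaves is replaced by a saturated ring of the same size, and the bromine is lost with it. Among the measured compounds every acyl group on this carbonyl is an aromatic ring, so no measured pair shows what a saturated ring does here.

For compound 4 a higher number than that of compound 1 is expected, a step of an 8.8-fold higher number from compound 1 to compound 4 (0.95 log units; beyond the scatter) in this assay, beyond the scatter. The estimate for compound 4 is 1500 nM, with a range from 300 nM to 8000 nM.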

Compound 4, half-maximal effective concentration: 46800 nM
For compound 4 the middle estimate is 31-fold (1.49 log units) below the measured one, outside the stated range (above it).
By their numbers in this assay, from the lowest: compound 3; then compounds 1 and 2 (each within the scatter of the next); then compound 4.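

In this assay, cyclohexyl in place of 2-bromophenyl on a carbonyl carbon gives a 280-fold higher number from compound 1 to compound 4 (2.44 log units; beyond the scatter), a large step from one change. The earlier compounds shown here all carry an aromatic ring on this carbonyl, so they could not show how much the number can depend on what sits here; this pair shows that a saturated ring of the same size is no close stand-in for the 2-bromophenyl group. Nothing shown here explains why the step is so large.

The aromatic ring and the bromine leave together in this one change, so the compounds shown cannot divide the step between the two; a plain phenyl on this carbonyl, with the ring kept and the bromine gone, would separate them. Also open, on these data alone, is how this position responds to groups of other kinds, such as a pyridyl ring, which keeps an aromatic ring but brings in a nitrogen, or a straight hexyl chain, which has no ring at all.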